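Aziridinyl quinone series: side-chain variation at the ring carbon

The compounds below may be only part of what the source reports. "The series", "measured", "known", "first", "only" and "open" are said of these compounds alone.

Measured compounds:
compound 1 `COCCC1=C(N2CC2)C(=O)C(C)=C(N2CC2)C1=O` 5.19
compound 2 `COCCC1=C(N2CC2)C(=O)C(CCOC)=C(N2CC2)C1=O` 5.18
compound 3 `CC1=C(N2CC2)C(=O)C(CCCc2ccccc2)=C(N2CC2)C1=O` 3.93

In a functional assay on L1210 cells (Mus musculus), with a stated time of 1 days (on this read-out higher numbers stand for higher potency (the scale is a negative logarithm) and lower numbers for lower potency), compound 1 stands highest of the three numbers; compound 2 lies within the scatter of it, and compound 3 lies well below it. The step of a number 0.01 log units lower from compound 1 to compound 2 (within the scatter) shows that adding a second chain of the same kind on the far ring carbon changes nothing beyond the scatter. The step of a number 1.26 log units lower from compound 1 to compound 3 (beyond the scatter) shows that swapping methoxy for benzyl two bonds along the chain costs a large amount.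

Compound 4 `COC(CO)C1=C(N2CC2)C(=O)C(C)=C(N2CC2)C1=O` is not yet measured. Its change from compound 1 is 2-hydroxy-1-methoxyethyl in place of 2-methoxyethyl on a double-bonded ring carbon. Among the compounds with values here, no measured step tests a hydroxyl on this chain or a methoxy moved one carbon closer to the ring; the only close comparison is compound 2, whose step from compound 1 was flat, while compound 3 warns that a larger, non-oxygen group in this region is costly. Since the entering group keeps a methoxy and stays small, the expected step is a number 0.09 log units lower from compound 1 to compound 4 (within the scatter), that is, none beyond the scatter, with a wide range. The estimate for compound 4 is 5.1, between 4.6 and 5.6.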

Compound 4, logarithm of the reciprocal of the active concentration, log(1/C): 6.05
For compound 4 the middle estimate is 0.95 log units below the measured one, and the stated range ends below it.
By their numbers in this assay, from the lowest: compound 3; then compounds 2 and 1 (each within the scatter of the next); then compound 4.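

In this assay the chain on the double-bonded ring carbon next to the ring atom that bears an aziridin-1-yl group proves able to raise the number: a number 0.86 log units higher from compound 1 to compound 4 (beyond the scatter) is the only upward step among the compounds shown, since the earlier steps were flat or downward. The change is double, however, adding a hydroxyl and shifting the methoxy one carbon closer to the ring, so this step alone cannot assign the rise to either part. Nothing available here bears on the reason for the rise.

A 2-hydroxyethyl or a 1-methoxyethyl chain would separate the two parts of the change. Also open, from the compounds shown here alone, are whether an amine can stand in place of the hydroxyl and whether a longer chain carrying the hydroxyl holds the gain.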